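Aryl substituent variation on the shared core

The source may report more compounds than this note shows. Statements on the series, on what has been measured and on what is new or still open speak of the compounds shown alone.

The series keeps one core and varies the aromatic ring on a saturated ring carbon. Compound 1 `CCN1CC[C@@]2(OC)OC(N)=C(C#N)[C@@H](c3ccccc3)[C@@H]2C1` carries plain phenyl; in a functional assay on trachea (Cavia porcellus) (a lower number here means a stronger inhibitor, a higher number a weaker inhibitor), compound 1 gives 23400 nM. Compound 2 `CCN1CC[C@@]2(OC)OC(N)=C(C#N)[C@@H](c3ccc(Cl)cc3Cl)[C@@H]2C1` carries 2,4-dichlorophenyl, and in this assay compound 2 gives 27100 nM. Compound 3 `CCN1CC[C@@]2(OC)OC(N)=C(C#N)[C@@H](c3ccc(C)cc3)[C@@H]2C1` carries 4-methylphenyl, and in this assay compound 3 gives 16800 nM, the lowest of the three numbers, though its gaps to the others, a 1.4-fold lower number from compound 1 to compound 3 (0.14 log units; within the scatter) and a 1.6-fold lower number from compound 2 to compound 3 (0.21 log units; within the scatter), both lie within the scatter, as does a 1.2-fold higher number from compound 1 to compound 2 (0.06 log units; within the scatter). Compound 3 thus stands together with compounds 1 and 2 rather than apart from them.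

Compound 4 `CCN1CC[C@@]2(OC)OC(N)=C(C#N)[C@@H](c3ccc(N4CCCCC4)cc3)[C@@H]2C1` differs from compound 3 in one place: piperidin-1-yl in place of methyl on an aromatic carbon. The measured steps that bear on this are the changes on the same aromatic ring, a 1.4-fold lower number from compound 1 to compound 3 (0.14 log units; within the scatter), a 1.2-fold higher number from compound 1 to compound 2 (0.06 log units; within the scatter) and a 1.6-fold lower number from compound 2 to compound 3 (0.21 log units; within the scatter), none of which moved the number beyond the scatter. No substitution on this ring has so far produced a step of any size, so no step beyond the scatter is expected here either, although piperidin-1-yl is a larger group than any tried before. The expected step is a 1.1-fold higher number from compound 3 to compound 4 (0.03 log units; within the scatter). Compound 4 is accordingly estimated at 18000 nM, with a range from 6000 nM to 54000 nM.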

Compound 4, half-maximal inhibitory concentration: 13800 nM
The estimate for compound 4 lay 1.3-fold (0.12 log units) above the measured number; the range from low to high includes it.
By their numbers in this assay, from the lowest: compounds 4, 3, 1 and 2 (each within the scatter of the next).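

Working notes on the aryl position: the carbon para to a large group now holds piperidin-1-yl, a six-membered non-aromatic ring with a nitrogen and a hydrogen-bond acceptor, which is a much larger change than any earlier one on this ring. Even so, in this assay the number does not move beyond the scatter, either against methyl (a 1.2-fold lower number from compound 3 to compound 4 (0.09 log units; within the scatter)) or against the unsubstituted ring (a 1.7-fold lower number from compound 1 to compound 4 (0.23 log units; within the scatter)), so this position accepts a bulky cyclic amine as readily as it accepts methyl or the 2,4-dichloro pattern, and all four compounds remain one flat group. No available data bear on why the number stays flat across these groups.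

The compounds shown leave open whether a carboxylic acid or a primary amine at this same ring carbon would produce a step beyond the scatter. They also leave open whether replacing the ethyl, methoxy or nitrile groups of the shared core, for instance with a longer chain in place of ethyl, would shift the number where changes to the aromatic ring have not.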